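The source may hold more compounds than are shown below. What is called first, only, known or untested is meant among the compounds shown, and "the series" means these compounds.

Compounds measured in an assay on isolated protein for binding affinity to Equilibrative nucleoside transporter 1 (Homo sapiens); on this read-out higher numbers stand for weaker inhibition and lower numbers for stronger inhibition: compound 1, `Cc1ccc(CSc2ncnc3c2ncn3[C@@H]2O[C@H](CO)[C@@H](O)[C@H]2O)cc1`, gives 457 nM. Compound 2, `OC[C@H]1O[C@@H](n2cnc3c(CSc4ccccc4Cl)ncnc32)[C@H](O)[C@@H]1O`, gives 1780 nM. Compound 3, `OC[C@H]1O[C@@H](n2cnc3c(CSc4ccccc4F)ncnc32)[C@H](O)[C@@H]1O`, gives 355 nM.

Compound 3 stands at the low end of these three numbers. Its gap to compound 1, a 1.3-fold lower number from compound 1 to compound 3 (0.11 log units; within the scatter), lies within the scatter, so the two cannot be told apart on this read-out. Compound 2 is clearly separated from it, a 5.0-fold lower number from compound 2 to compound 3 (0.70 log units; beyond the scatter), and compound 2 is also separated from compound 1, a 3.9-fold higher number from compound 1 to compound 2 (0.59 log units; beyond the scatter).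

Compound 4, `OC[C@H]1O[C@@H](n2cnc3c(CSc4ccccc4I)ncnc32)[C@H](O)[C@@H]1O`, differs from compound 3 by iodo in place of fluoro on an aromatic carbon. Within the data shown here, only one measured step bears on this exchange of one halogen for another at the same place: a 5.0-fold lower number from compound 2 to compound 3 (0.70 log units; beyond the scatter), where fluoro in place of chloro brought the number down by a modest amount. Among the measured compounds shown here, the step to compound 4 runs in the opposite sense, away from fluoro, and the single precedent points to a rise rather than a fall in this assay, of a size comparable to that step. Whether iodo behaves like chloro here is not known from these compounds, so the range is wide.

Compound 4 is therefore expected to give about 1500 nM, somewhere between 500 nM and 5000 nM. That estimate amounts to an expected step of a 4.2-fold higher number from compound 3 to compound 4 (0.63 log units; beyond the scatter), a modest rise beyond the scatter.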

Compound 4, half-maximal inhibitory concentration: 282 nM
For compound 4 the middle estimate is 5.3-fold (0.73 log units) above the measured one; measured number outside the range, below it.
By their numbers in this assay, from the lowest: compounds 4, 3 and 1 (each within the scatter of the next); then compound 2.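

In this assay, the halogen on this aromatic carbon, ortho to a large group, does not follow a simple order: iodo in place of fluoro gives a pair that cannot be told apart (a 1.3-fold lower number from compound 3 to compound 4 (0.10 log units; within the scatter)), whereas iodo in place of chloro gives a clear separation (a 6.3-fold lower number from compound 2 to compound 4 (0.80 log units; beyond the scatter)). The earlier fluoro and chloro pair alone could have suggested that the number climbs as the halogen changes from fluoro onward, but compound 4 goes against that reading, and among the three 2-halophenyl compounds only the chloro compound 2 stands apart. Compound 4 also stays within the scatter of compound 1 (a 1.6-fold lower number from compound 1 to compound 4 (0.21 log units; within the scatter)), so the 2-iodophenyl compound and the compound with the (4-methylbenzyl)sulfanyl group cannot be separated on this read-out.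

No evidence at hand accounts for the chloro compound standing apart from the fluoro and iodo compounds. As far as these compounds go, whether bromo, methyl or an amine at this same place would sit with fluoro and iodo or with chloro remains open.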